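The compounds below may be only part of what the source reports. "The series", "measured", "known", "first", "only" and "open" are said of these compounds alone.

Going by the values given here, compound 1 `Cc1cc(C)cc(NC(=O)COc2cc(C)nc3ccccc23)c1` is one of two compounds measured in a physicochemical assay for lipophilicity, read by HPLC, in phosphate buffer, measured as chromatographic lipophilicity, at pH 7.4 (a lower number here means a more polar compound, a higher number a more lipophilic compound), so far; in this assay compound 1 gives 5.39 and stands as the lowest of the two numbers. Among the compounds with values here, the only other measured compound is compound 2 `COc1ccc2c(OCC(=O)Nc3cc(C)cc(C)c3)cc(C)nc2c1` which in this assay gives 5.59 and the one recorded step, methoxy in place of hydrogen on an aromatic carbon, is a number 0.20 log units higher from compound 1 to compound 2 (within the scatter) and so does not separate the pair beyond the scatter.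

Compound 3 `Cc1cc(C)cc(NC(=O)COc2cc(C)nc3ccc(F)cc23)c1` has yet to be measured in this assay. It differs from compound 1 by fluoro in place of hydrogen on an aromatic carbon so the difference is a single fluorine on the core shared with compound 1. Within the data shown here, no measured step concerns a fluoro substitution directly; the methoxy step on a nearby ring carbon is the only comparison available and it stayed small. A small step in this assay is therefore expected for compound 3 relative to compound 1, if anything upward, on the order of a number 0.16 log units higher from compound 1 to compound 3 (within the scatter) which would remain within the scatter. The value expected for compound 3 in this assay is 5.55 with a range from 5.25 to 5.85 for the estimate.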

Compound 3, distribution coefficient: 5.79
For compound 3 the middle estimate is 0.24 log units below the measured one; low and high end bracket the measured number.
By their numbers in this assay, from the lowest: compounds 1, 2 and 3 (each within the scatter of the next, the first and the last beyond it).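

In this assay, going by these compounds alone, fluoro in place of hydrogen on this aromatic carbon gives a number 0.40 log units higher from compound 1 to compound 3 (beyond the scatter) and this modest step is the first to lie beyond the scatter. A change of one heavy atom on the shared core is thus enough to move this read-out measurably, something the methoxy step (a number 0.20 log units higher from compound 1 to compound 2 (within the scatter)) could not show while it stayed within the scatter. No measurement at hand bears on what lies behind the step.

Open, going by these compounds, is whether chloro, trifluoromethyl or an amine on the same carbon would give a step of similar size or direction. Also open, on these data alone, is what fluoro would give on another carbon of the shared core, and whether the step would hold with a different group in place of the dimethyl-substituted anilide part.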